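Removing a methyl from an oxygen: hydroxy in place of methoxy

The compounds below may be only part of what the source reports. "The series", "measured", "known", "first", "only" and "open" are said of these compounds alone.

Of the compounds shown here, two sharing one core have been tested in a functional assay on SN12C cells (Homo sapiens) for cytotoxicity, read by sulforhodamine B assay, with a stated time of 48 h, tested at 0.01 uM; on this read-out lower numbers stand for a stronger effect and higher numbers for a weaker effect at the one concentration tested. Compound 1 `Cc1cc(O)cc(-c2nn(CC#N)cc2-c2ccnc(-c3ccc(Oc4ccccc4)cc3)c2)c1` gives 88% in this assay. Compound 2 `COc1cc(C)cc(-c2nn(CC#N)cc2-c2ccnc(-c3ccc(N(C)C)cc3)c2)c1` gives 90% in this assay. These two numbers lie within the usual scatter of each other, so on the numbers shown compound 2 cannot be set apart from compound 1; both sit high on this read-out, meaning only a weak effect at the single concentration tested.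

Compound 3 `Cc1cc(O)cc(-c2nn(CC#N)cc2-c2ccnc(-c3ccc(N(C)C)cc3)c2)c1` has not yet been measured in this assay. It differs from compound 2 in one place: hydrogen in place of methyl on an oxygen on an aromatic ring. No measured pair that differs in this way is available, so nothing from the numbers shown says how this change behaves. The two measured compounds both give high readings in this assay, and compound 3 is expected to stay near them, with a step of a number 2 percentage points lower from compound 2 to compound 3 (within the scatter) that is expected to be no larger than the scatter. Compound 3 is therefore estimated to give 88% in this assay, within a range from 76% to 98%.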

Compound 3, a percentage reported as activity, at one concentration (the size of the read-out at that concentration, not a potency): 90%
Compound 3: middle estimate off by 2 percentage points, on the low side; the range from low to high includes it.
By their numbers in this assay, from the lowest: compounds 1, 2 and 3 (each within the scatter of the next).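

In this assay, among these compounds, putting hydrogen in place of methyl on the oxygen gives no change at the digits printed from compound 2 to compound 3 (within the scatter) and so provides the first measured pair that differs only at this spot, showing that methoxy and hydroxy cannot be told apart here when the rest of the molecule carries dimethylamino. Dimethylamino in place of phenoxy on an aromatic carbon, at the other end of the molecule, gives a number 2 percentage points higher from compound 1 to compound 3 (within the scatter) and likewise leaves the two compounds inseparable at this one low concentration, where all three readings remain high and the effect weak. No independent measurement is available to explain why either change leaves the reading within the scatter.

Still open, as far as these compounds go, is whether a longer chain on this oxygen, such as ethoxy, or a different group in place of the oxygen, such as an amine or a carboxylic acid, would move the reading beyond the scatter. A single concentration with weak effects also leaves open whether methoxy and hydroxy would still match at higher concentrations, where a stronger effect might show a difference.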